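Adding chloro to the anilino group of compound 1

The source may report more compounds than this note shows. Statements on the series, on what has been measured and on what is new or still open speak of the compounds shown alone.

Compound 1 `Fc1cccc(-c2nc(Nc3ccccc3)c3cc(F)ccc3n2)c1`: 45500 nM
Compound 2 `Fc1cccc(Nc2nc(-c3cccc(F)c3)nc3ccc(F)cc23)c1`: 42300 nM
Compound 3 `Fc1cccc(-c2nc(Nc3cccc(Cl)c3)c3cc(F)ccc3n2)c1`: > 50000 nM (a limit of the assay)

In a functional assay on U-937 cells (Homo sapiens) for cytotoxicity, read by MTT assay, with a stated time of 48 h (a lower number here means a stronger inhibitor, a higher number a weaker inhibitor), compound 1 has a single numerical neighbour, and the gap is a 1.1-fold lower number from compound 1 to compound 2 (0.03 log units; within the scatter). Compound 3 gave only a limit, > 50000 nM, and not a number.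

Compound 4 `Fc1cccc(-c2nc(Nc3ccccc3Cl)c3cc(F)ccc3n2)c1` has not yet been measured. It differs from compound 1 by chloro in place of hydrogen on an aromatic carbon, ortho to a large group, which reads as anilino to (2-chlorophenyl)amino.

The closest measured change is the same kind of exchange made at a different place, giving an at least 1.0-fold higher number from compound 1 to compound 3 (0.04 log units; that floor lies within the scatter). The exchange of fluoro for chloro gives an at least 1.1-fold higher number from compound 2 to compound 3 (0.07 log units; that floor lies within the scatter). Neither step shows a change beyond the scatter, so none is expected for this new chloro in this assay, although another limit is quite possible.

For compound 4 the expected value is 45000 nM, with an estimated range of 25000 nM to 60000 nM. This estimate means an expected 1.0-fold lower number from compound 1 to compound 4 (0.00 log units; within the scatter).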

Compound 4, half-maximal inhibitory concentration: > 50000 nM
Compound 4 ended at the assay's limit; the forecaster's own chance of this, stated with the estimate: 45%; middle value at least 1.1-fold (0.04 log units) from the limit.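

In this assay, a chloro on an aromatic carbon ortho to a large group ends the same way as the chloro of compound 3, in a limit and not a number, and the step reads an at least 1.0-fold higher number from compound 1 to compound 4 (0.04 log units; that floor lies within the scatter). Set against the 3-fluorophenyl group of compound 2, the 2-chlorophenyl group gives an at least 1.1-fold higher number from compound 2 to compound 4 (0.07 log units; that floor lies within the scatter), so neither floor lies beyond the scatter, while the step between the two chloro compounds cannot be read. This position therefore adds a second chloro placement on the anilino ring that yields no readable strengthening, and the readout now stops at one shared ceiling: the limit of > 50000 nM in this assay, at which 2 of the 4 values shown sit.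

As far as these compounds go, how far compound 3 and compound 4 lie past that limit stays unknown, so the two chloro placements cannot be told apart. From the compounds shown here alone, whether an amine or a carboxylic acid on this ring would give a readable number also stays open.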